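The source may report more compounds than this note shows. Statements on the series, on what has been measured and on what is new or still open speak of the compounds shown alone.

The set consists of four compounds on one shared core, examined in a functional assay on PANC-1 cells (Homo sapiens) for inhibition, read by MTT assay, with a stated time of 24 h, tested at 10 uM; a lower number here means less inhibition, a higher number more inhibition at the concentration tested (going by the name of the read-out). Compound 1 `CC(C)=CCC1Cc2c(OC(=O)Nc3ccc(F)cc3)cc(=O)n(CCCO)c2CC1(C)C` carries the (4-fluorophenyl)carbamoyl group on the ring oxygen and gives 0%. Compound 2 `CC(C)=CCC/C(C)=C/COc1cc(=O)n(CCCO)c2c1CC(C/C=C(\C)CCC=C(C)C)C(C)(C)C2` bears the 2,6-dimethylhepta-1,5-dien-1-yl group at that oxygen and gives 3.1%. Going by the values given here, compound 3 `COc1ccc(OCCCOc2cc(=O)n(CCCO)c3c2CC(C/C=C(\C)CCC=C(C)C)C(C)(C)C3)cc1`, with the 3-(4-methoxyphenoxy)propyl group on the same oxygen, gives 0%; it stands level with compound 1 at the digits reported, and the single measured step, a number 3.1 percentage points lower from compound 2 to compound 3 (within the scatter), lies within the scatter. All three values are low.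

Compound 4 `CC(C)=CCC/C(C)=C/CC1Cc2c(OC(=O)Nc3ccc(F)cc3)cc(=O)n(CCCO)c2CC1(C)C` is the unmeasured member. It differs from compound 3 by (4-fluorophenyl)carbamoyl in place of 3-(4-methoxyphenoxy)propyl on an oxygen on an aromatic ring. Among the compounds with values here, no measured step covers this exact exchange. Two observations bear on it: compound 1, which carries the same (4-fluorophenyl)carbamoyl on the ring oxygen, gives 0%, and the step of a number 3.1 percentage points lower from compound 2 to compound 3 (within the scatter) shows that an exchange of the group on this oxygen left the read-out within the scatter. A step of no size beyond the scatter is therefore expected, and a number 2 percentage points higher from compound 3 to compound 4 (within the scatter) is the estimated change. Compound 4 is expected to give 2%, within a range from 0% to 12%.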

Compound 4, a percentage reported as inhibition, at one concentration (the size of the read-out at that concentration, not a potency): 6.2%
Compound 4: the middle estimate sits 4.2 percentage points below what was measured; the range from low to high includes it.
By their numbers in this assay, from the lowest: compounds 1, 3, 2 and 4 (each within the scatter of the next).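

In this assay, a carbamoyl group now joins the ether groups on the oxygen on an aromatic ring: the (4-fluorophenyl)carbamoyl group gives a number 6.2 percentage points higher from compound 3 to compound 4 (within the scatter) and a number 3.1 percentage points higher from compound 2 to compound 4 (within the scatter) so neither exchange separates this group from 3-(4-methoxyphenoxy)propyl or 3,7-dimethylocta-2,6-dien-1-yl, even though it brings a hydrogen-bond donor that 3-(4-methoxyphenoxy)propyl lacks. Going by these compounds alone, the result also adds the first step at a second place, the saturated chain carbon bound to a double-bonded chain carbon, where 3-methylbut-2-en-1-yl in place of hydrogen gives a number 6.2 percentage points higher from compound 1 to compound 4 (within the scatter) and so also stays within the scatter. Nothing available accounts for these small differences, and no measurement beyond this read-out bears on them.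

All four compounds thus lie within the scatter of one another, which leaves open whether any change at either place can move the read-out beyond it. A group bearing an amine or a carboxylic acid on the same oxygen, or a much shorter chain such as methyl on the saturated chain carbon, would test this, and the compounds shown do not settle the outcome.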